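Nitro for Methyl on the Benzyl Ring of Compound 1

A few compounds are considered here, and "the series" means these few. Any claim that something is new, unique, unknown or untested is made for them only; others in the source may bear on it.

Compound 1, `COc1ccc(CN(C(=O)CSc2nc3ccccc3s2)c2cc(OC)c(OC)c(OC)c2)cc1C`: 34300 nM
Compound 2, `COc1cc(N(Cc2ccc(F)cc2)C(=O)CSc2nc3ccccc3s2)cc(OC)c1OC`: 50800 nM
Compound 3, `COc1cc(CN(C(=O)CSc2nc3ccccc3s2)c2cc(OC)c(OC)c(OC)c2)cc(OC)c1OC`: > 80000 nM

In a functional assay on PC-3 cells (Homo sapiens) for antiproliferative activity, read by MTT assay, with a stated time of 48 h (a lower number here means a stronger inhibitor, a higher number a weaker inhibitor), compound 1 has the lowest of the two numbers given. The value of compound 3 is a limit of the assay, not a number. Compound 4, `COc1ccc(CN(C(=O)CSc2nc3ccccc3s2)c2cc(OC)c(OC)c(OC)c2)cc1[N+](=O)[O-]`, differs from compound 1 by nitro in place of methyl on an aromatic carbon. Among the measured compounds shown here, no measured step makes this change; the three measured steps each exchange the whole aryl group on that saturated chain carbon: a 1.5-fold higher number from compound 1 to compound 2 (0.17 log units; within the scatter), an at least 2.3-fold higher number from compound 1 to compound 3 (0.36 log units; beyond the scatter) and an at least 1.5-fold higher number from compound 2 to compound 3 (0.19 log units; that floor lies within the scatter). Changes at this ring have so far given a higher number at most modestly, so the step to compound 4 is expected to be small, if any, toward a higher number: a 1.3-fold higher number from compound 1 to compound 4 (0.12 log units; within the scatter). Compound 4 is therefore estimated at 45000 nM, between 20000 nM and 95000 nM.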

Compound 4, half-maximal inhibitory concentration: 26500 nM
Compound 4: middle estimate off by 1.7-fold (0.23 log units), on the high side, within the range that was stated.
By their numbers in this assay, from the lowest: compounds 4, 1 and 2 (each within the scatter of the next). At a limit, above all of these: compound 3.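

In this assay, nitro in place of methyl, ortho to a methoxy group, gives a 1.3-fold lower number from compound 1 to compound 4 (0.11 log units; within the scatter), so this position takes three heavy atoms and two hydrogen-bond acceptors in place of one carbon without a change beyond the scatter. Exchanging the whole aryl group separates the 4-methoxy-3-nitrophenyl group from 4-fluorophenyl by no more than the scatter, with a 1.9-fold lower number from compound 2 to compound 4 (0.28 log units; within the scatter), but from 3,4,5-trimethoxyphenyl by more than the scatter, with an at least 3.0-fold lower number from compound 3 to compound 4 (0.47 log units; beyond the scatter). That last step rests on a limit, not a number: the limit of > 80000 nM in this assay, at which 1 of the 4 values shown sits.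

Going by these compounds, whether an amine or a carboxylic acid on this aromatic carbon would move the number beyond the scatter stays open. So does the part played by the 4-methoxy group on this ring.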